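The source may hold more compounds than are shown below. What is called first, only, known or untested is meant among the compounds shown, and "the series" means these compounds.

Working notes on the series in an ADME assay on Caco-2 cells (Homo sapiens) for inhibition, read by MTT assay, with a stated time of 72 h; on this read-out lower numbers stand for stronger inhibition and higher numbers for weaker inhibition. Compound 1 (`CCCNC(=C\C(=O)/C=C/c1ccc(O)c(OC)c1)/C=C/c1ccc(O)c(OC)c1`) gives > 25000 nM, which is a limit of the assay and not a number. Compound 2 (`CC(=O)Oc1ccc(/C=C/C(=O)/C=C(/C=C/c2ccc(OC(C)=O)cc2)NCC(C)C)cc1`) gives > 25000 nM, also a limit. Compound 3 (`CCC(C)NC(=C\C(=O)/C=C/c1ccc(OC(C)=O)c(OC)c1)/C=C/c1ccc(OC(C)=O)c(OC)c1`) gives > 25000 nM, again a limit. Going by the values given here, the overall picture is the limit of > 25000 nM in this assay, at which 3 of the 3 values shown sit, so no compound in hand offers a number, and no order among the three can be drawn.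

Compound 4 (`CCCCNC(=C\C(=O)/C=C/c1ccc(O)c(OC)c1)/C=C/c1ccc(O)c(OC)c1`) is the next to be read. It differs from compound 1 by methyl in place of hydrogen on a saturated chain carbon, three bonds along the chain from an amine nitrogen, which takes propyl to butyl. Among the compounds with values here, no measured pair tests this change.

In this assay, no step beyond the scatter is expected, in either direction. That expectation rests on compound 1, which reads > 25000 nM, and on the small size of the change. The estimated step that the limit leaves unreadable from compound 1 to compound 4 is therefore expected to stay small. For compound 4 the estimated value is 30000 nM, with an expected range from 12000 nM to 60000 nM, and a report of only a limit is the likeliest outcome.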

Compound 4, half-maximal inhibitory concentration: > 25000 nM
Compound 4: only a limit was reported (the forecaster's own chance of this, stated with the estimate: 75%); the middle value lies beyond the limit too.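

Compound 1 and compound 4 both stand at a limit of the assay and not at a number, so the step from propyl to butyl cannot be read. The compounds shown leave open which structural change, if any, would give a measurable value in this assay: the limit of > 25000 nM in this assay, at which 4 of the 4 values shown sit.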